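A few compounds are considered here, and "the series" means these few. Any claim that something is new, unique, unknown or untested is made for them only; others in the source may bear on it.

Working notes on the series. In a functional assay on KG-1 cells (Homo sapiens) for inhibition, read by MTT assay, with a stated time of 48 h (a lower number here means a stronger inhibitor, a higher number a weaker inhibitor), compound 1 (`O=S(=O)(c1ccccc1)c1c(OCCCCCCO)no[n+]1[O-]`) is recorded as "not determined" (no result reported), so it offers no number for comparison. Compound 2 (`O=C(CCCCCCOc1no[n+]([O-])c1S(=O)(=O)c1ccccc1)NO`) gives 4270 nM. Among the compounds with values here, this is the only number available so far, which leaves compound 2 without a measured neighbour against which to rank it as strong or weak.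

Compound 3 (`O=C(CCCCCCCOc1no[n+]([O-])c1S(=O)(=O)c1ccccc1)NO`) differs from compound 2 in one place: (hydroxycarbamoyl)methyl in place of hydroxycarbamoyl on a saturated chain carbon, six bonds along the chain from an oxygen on an aromatic ring. The same change can be read as 3-(hydroxycarbamoyl)propyl to 4-(hydroxycarbamoyl)butyl, and the hydroxycarbamoyl end itself is retained.

Within the data shown here, no measured step shows what such a change does in this assay, so the size and direction below are a weakly held expectation. A small move toward stronger inhibition is expected, not clearly beyond the scatter, and a move the other way cannot be excluded. The estimated change is a 1.7-fold lower number from compound 2 to compound 3 (0.23 log units; within the scatter). For compound 3, the estimated value is 2500 nM, with an expected range of 800 nM to 7000 nM.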

Compound 3, half-maximal inhibitory concentration: 630 nM
For compound 3 the middle estimate is 4.0-fold (0.60 log units) above the measured one; the measured number lies below the stated range.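

In this assay, within the data shown here, (hydroxycarbamoyl)methyl in place of hydroxycarbamoyl on a saturated chain carbon, six bonds along the chain from an oxygen on an aromatic ring, gives a 6.8-fold lower number from compound 2 to compound 3 (0.83 log units; beyond the scatter), the first measured step and one that shows this position responds to the change. The hydroxycarbamoyl end is retained on both sides, so the step goes with the 3-(hydroxycarbamoyl)propyl to 4-(hydroxycarbamoyl)butyl change in chain length and not with a change of end group. Nothing on hand accounts for the size of this step, so it stands as an observation without an explanation.

A single step gives a direction only between these two chain lengths, and the compounds shown leave open whether a longer chain, such as 5-(hydroxycarbamoyl)pentyl, would continue the trend, level off or reverse it. They also leave open whether the hydroxycarbamoyl end is needed at all, which a carboxylic acid or a primary amide at the end of the 4-(hydroxycarbamoyl)butyl chain length would help to settle.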